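The source may hold more compounds than are shown below. What is called first, only, known or untested is meant among the compounds shown, and "the series" means these compounds.

In an ADME assay on HUVEC cells (Homo sapiens) for cytotoxicity, read by MTT assay, with a stated time of 48 h (a lower number here means a stronger inhibitor, a higher number a weaker inhibitor), compound 1 `Nc1nc(-c2ccccc2)cn1/N=C/c1cc2ccccc2nc1Cl` gives 46700 nM. Compound 2 `Cc1ccc(-c2cn(/N=C/c3cc4ccccc4nc3Cl)c(N)n2)cc1` reaches only the limit of this assay, > 50000 nM, so for compound 2 no number is known, only that limit. Among the measured compounds shown here, the single measured step, an at least 1.0-fold higher number from compound 1 to compound 2 (0.02 log units; that floor lies within the scatter), is known only as a floor because of the limit of > 50000 nM in this assay, at which 1 of the 2 values shown sits. Compound 3 `COc1ccc(-c2cn(/N=C/c3cc4ccccc4nc3Cl)c(N)n2)cc1` differs from compound 2 by methoxy in place of methyl on an aromatic carbon. Since an at least 1.0-fold higher number from compound 1 to compound 2 (0.02 log units; that floor lies within the scatter) stays within the scatter, compound 3 is expected to show no step beyond the scatter either, a number no higher from compound 2 to compound 3 (the limit leaves the size open). Compound 3 is therefore estimated at 50000 nM, with a range from 15000 nM to 150000 nM.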

Compound 3, half-maximal inhibitory concentration: 12400 nM
The estimate for compound 3 lay 4.0-fold (0.61 log units) above the measured number, and the stated range ends above it.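

Among the compounds shown here, at this position, para to a large group, the change to 4-methoxyphenyl gives the first step beyond the scatter in this assay, with an at least 4.0-fold lower number from compound 2 to compound 3 (0.60 log units; beyond the scatter). Measured against hydrogen, methoxy also gives a step beyond the scatter, with a 3.8-fold lower number from compound 1 to compound 3 (0.58 log units; beyond the scatter), so this position responds to what is placed on it, which the earlier pair could not show. The step from methyl is only a floor: the limit of > 50000 nM in this assay, at which 1 of the 3 values shown sits.

The compounds shown leave open how an amine, a carboxylic acid or a longer chain such as ethoxy would read at this position.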